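Swapping the Formylpiperidinyl Arm for a Hydroxymethyl Isoxazole

A few compounds are considered here, and "the series" means these few. Any claim that something is new, unique, unknown or untested is made for them only; others in the source may bear on it.

Measured so far:
Compound 1, `O=CN1CCC(c2ccc(-c3cc(C(=O)O)cc4cc(-c5ccc(C(F)(F)F)cc5)ccc34)cc2)CC1`, in an assay on isolated protein for binding affinity to Sigma non-opioid intracellular receptor 1 (Homo sapiens) (a higher number here means a weaker inhibitor, a lower number a stronger inhibitor), gives 759 nM.
Compound 2, `O=C(O)c1cc(-c2ccc(NC(=O)C3CCNCC3)cc2)cc(-n2cc(-c3ccc(C(F)(F)F)cc3)nn2)c1`, in this assay gives 2330 nM.

Of these two numbers, compound 1 holds the lower one, and the gap to compound 2 lies beyond the usual scatter, so compound 1 stands as the stronger binder of the pair. The next compound, compound 3, `O=C(O)c1cc(-c2ccc(-c3cc(CO)on3)cc2)c2ccc(-c3ccc(C(F)(F)F)cc3)cc2c1`, is built on the core of compound 1 and differs from it in one place: 5-(hydroxymethyl)-1,2-oxazol-3-yl in place of 1-formylpiperidin-4-yl on an aromatic carbon. Among the compounds with values here, no two measured compounds differ by exactly this exchange, so there is no measured step to lean on; what can be said rests on compound 1 alone, which gives 759 nM in this assay, and on the fact that compound 2, with its own different substitution, gives 2330 nM. With the anchor set by compound 1, the step from compound 1 to compound 3 is expected to be modest, leaning toward a weaker inhibitor rather than a stronger one, a 1.6-fold higher number from compound 1 to compound 3 (0.20 log units; within the scatter), though a result within the scatter would not surprise. Compound 3 is accordingly estimated at 1200 nM, with a plausible range from 400 nM to 4000 nM.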

Compound 3, inhibition constant: 2680 nM
Compound 3: the middle estimate sits 2.2-fold (0.35 log units) below what was measured, and the stated range covers the measured number.
By their numbers in this assay, from the lowest: compound 1; then compounds 2 and 3 (each within the scatter of the next).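

Within the data shown here, this exchange gives the first reading of what the aromatic carbon para to a large group tolerates on the core of compound 1: in this assay, 5-(hydroxymethyl)-1,2-oxazol-3-yl in place of 1-formylpiperidin-4-yl gives a 3.5-fold higher number from compound 1 to compound 3 (0.55 log units; beyond the scatter). The position is therefore not indifferent to what it carries, since a step beyond the scatter separates these two groups, with the one bearing the six-membered non-aromatic ring giving the stronger binding. The exchange alters the ring, the hetero atoms and the counts of hydrogen-bond donors and acceptors all at once, and no measurement at hand accounts for the step.

The compounds shown leave open whether the step belongs to the five-membered aromatic ring or to its hydroxymethyl arm, a question that the same ring carrying an aminomethyl group or a carboxylic acid in that place would address. They also leave open how much of the binding of compound 1 depends on the formyl group, which an acetyl group or a free piperidine amine on the same ring would help to show.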